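The source may report more compounds than this note shows. Statements on the series, on what has been measured and on what is new or still open speak of the compounds shown alone.

Of the compounds shown here, three built on one shared core have been tested in a functional assay on HTB-54 cells (Homo sapiens) for cytotoxicity, read by MTT assay, with a stated time of 72 h; on this read-out higher numbers stand for weaker inhibition of growth and lower numbers for stronger inhibition of growth. Compound 1, `CCCCC[Se]c1nc(NCc2ccc(SC)cc2)c2ccccc2n1`, gives 81300 nM in this assay. Compound 2, `CSc1ccc(CNc2nc([SeH])nc3ccccc23)cc1`, returns only a limit of the assay, > 100000 nM. Going by the values given here, the single measured step, an at least 1.2-fold higher number from compound 1 to compound 2 (0.08 log units; that floor lies within the scatter), is thus known only as a floor. Compound 3, `Sc1nc(NCc2ccccc2)c2ccccc2n1`, likewise returns a limit rather than a number, > 100000 nM. Where compound 3 stands is fixed by the limit of > 100000 nM in this assay, at which 2 of the 3 values shown sit; with no numerical value for compound 3, any step away from it can be judged only against that limit.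

Compound 4, `CSc1nc(NCc2ccccc2)c2ccccc2n1`, differs from compound 3 by methyl in place of hydrogen on a sulfur. Among the compounds with values here, the only measured step that bears on this is the change on selenium, an at least 1.2-fold higher number from compound 1 to compound 2 (0.08 log units; that floor lies within the scatter), which runs the opposite way, removing pentyl rather than adding methyl, and whose floor lies within the scatter. Read backwards, its direction would hint at a somewhat lower number on adding methyl, but the evidence is thin and compound 3 is itself only a limit. Compound 4 is therefore expected to give 90000 nM, within 40000 nM to 200000 nM, in this assay. The expected step, an at least 1.1-fold lower number from compound 3 to compound 4 (0.04 log units; that floor lies within the scatter), is estimated to be modest at most, with a real chance that compound 4 also returns only a limit.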

Compound 4, concentration for total growth inhibition: 82300 nM
Compound 4: middle estimate off by 1.1-fold (0.04 log units), on the high side, within the range that was stated.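

Until now, the sulfur position was known only in its hydrogen form, and compound 4 shows that with methyl on that sulfur the compound gives a real number in this assay rather than a limit, just as the pentyl-bearing compound 1 does on selenium while its hydrogen partner, compound 2, does not. The change itself can be stated only as an at least 1.2-fold lower number from compound 3 to compound 4 (0.08 log units; that floor lies within the scatter), so the data do not establish that methyl strengthens growth inhibition, only that any such effect could range from negligible to larger than this floor. The true size of the step stays unknown because the hydrogen form, compound 3, sits at a limit rather than a number: the limit of > 100000 nM in this assay, at which 2 of the 4 values shown sit.

The compounds shown leave open how the number would respond to a longer chain on this sulfur, such as butyl, or to a chain ending in an amine or a carboxylic acid. They also leave open whether any group on this sulfur can move the number clearly beyond the scatter, which is what a firm link between this position and growth inhibition would need.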